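Ethyl in Place of Iodo on Compound 1

The source may hold more compounds than are shown below. What is called first, only, known or untested is meant among the compounds shown, and "the series" means these compounds.

Measured in a functional assay on MCF7 cells (Homo sapiens) for inhibition, read by sulforhodamine B assay; a lower number here means a stronger inhibitor, a higher number a weaker inhibitor:
- Compound 1 `O=C1C(Nc2ccc(I)cc2)=CC(=O)c2c1nc1n2[C@H]2OC[C@@H](O)[C@H]2OC1` gives 3890 nM
- Compound 2 `O=C1C=C(N2CCC2)C(=O)c2c1nc1n2[C@H]2OC[C@@H](O)[C@H]2OC1` gives > 16000 nM, a limit of the assay

Compound 1 is the only one of the two with an actual number in this assay. Compound 2 is reported only as a limit, (the limit of > 16000 nM in this assay, at which 1 of the 2 values shown sits).

Compound 3 `CCc1ccc(NC2=CC(=O)c3c(nc4n3[C@H]3OC[C@@H](O)[C@H]3OC4)C2=O)cc1` keeps the core of compound 1 and carries ethyl in place of iodo on an aromatic carbon, para to a large group: ethyl in place of iodo on an aromatic carbon. Within the data shown here, no measured pair isolates this change, so the expectation rests on compound 1 at 3890 nM alone. The expected size of a 1.3-fold higher number from compound 1 to compound 3 (0.11 log units; within the scatter) is small, slightly towards a weaker inhibitor and probably not beyond the usual scatter. Compound 3 is estimated at 5000 nM, with an expected range from 2000 nM to 14000 nM.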

Compound 3, half-maximal inhibitory concentration: 8990 nM
Compound 3: the middle estimate sits 1.8-fold (0.25 log units) below what was measured; the measured number falls inside the stated range.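

Among these compounds, the pair of compound 1 and compound 3 gives the first measured step at this position. In this assay ethyl in place of iodo on the aromatic carbon para to a large group brings a 2.3-fold higher number from compound 1 to compound 3 (0.36 log units; beyond the scatter) and so shows that the group held here does move the number, with iodo the better of the two. Nothing measured among the compounds shown accounts for this step.

As far as these compounds go, whether a methoxy group, a chlorine or a carboxylic acid at this place would move the number further stays open, as does the effect of a chain longer than ethyl. Among the compounds shown here, with only two groups compared at this position, no trend across groups can be drawn.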